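Replacing the acylsulfonamide of compound 1 with a cyanomethyl ketone

The source may hold more compounds than are shown below. What is called first, only, known or untested is meant among the compounds shown, and "the series" means these compounds.

Measured compounds:
compound 1 `CCCCC(CC)C(=O)Nc1ccc2ccn(Cc3ccc(C(=O)NS(=O)(=O)c4ccccc4)cc3OC)c2c1` — 8.6
compound 2 `CCCCC(CC)C(=O)Nc1ccc2ccn(Cc3ccc(C(=O)NS(=O)(=O)c4ccc([N+](=O)[O-])cc4)cc3OC)c2c1` — 7.7
compound 3 `CCCCC(CC)C(=O)Nc1ccc2ccn(Cc3ccc(C(=O)NS(=O)(=O)c4ccccc4)cc3)c2c1` — 6.8

In a functional assay (trachea) for antagonist activity, with Cavia porcellus as the target (a higher number here means a more potent compound, by a factor of ten per unit of this negative logarithm, a lower number a less potent compound), compound 1 gives 8.6, the highest of the three numbers. Compound 2 lies nearest: a number 0.90 log units lower from compound 1 to compound 2 (beyond the scatter). Compound 3 lies furthest: a number 1.80 log units lower from compound 1 to compound 3 (beyond the scatter).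

Compound 4 `CCCCC(CC)C(=O)Nc1ccc2ccn(Cc3ccc(C(=O)C(C#N)S(=O)(=O)c4ccccc4)cc3OC)c2c1` has not yet been measured in this assay. It differs from compound 1 in one place: cyano(phenylsulfonyl)methyl in place of (phenylsulfonyl)amino on a carbonyl carbon. Neither measured step touches this place. The step from compound 1 to compound 2 alters the phenyl of the leaving group at an aromatic carbon and is modest; the step from compound 1 to compound 3 alters the methoxy-bearing ring and is large. The change to compound 4 is of a different kind, removing the hydrogen-bond donor of the (phenylsulfonyl)amino group and inserting a nitrile-bearing carbon between the carbonyl and the sulfur. Within the data shown here, with no step of this kind measured, the two measured steps show only that this series is sensitive to alteration near the carbonyl; a downward step beyond the scatter is expected. Compound 4 is therefore expected to give 7.3, within 6.3 to 8.3. This estimate means a step of a number 1.30 log units lower from compound 1 to compound 4 (beyond the scatter).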

Compound 4, negative logarithm of the antagonist equilibrium constant: 8.1
Estimate against measurement, compound 4: 0.80 log units below; measured number inside the range.
By their numbers in this assay, from the lowest: compound 3; then compound 2; then compound 4; then compound 1.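

In this assay, the change on the carbonyl carbon from (phenylsulfonyl)amino to cyano(phenylsulfonyl)methyl gives a number 0.50 log units lower from compound 1 to compound 4 (beyond the scatter), the only step shown at this place. The earlier compounds shown here altered only the phenyl of the leaving group or the methoxy-bearing ring, so they could not show that the (phenylsulfonyl)amino group can be replaced here with a real but modest loss: compound 4, whose new group has no hydrogen-bond donor, still gives 8.1. No measurement offered here accounts for the size of this step.

The hydrogen-bond donor, the nitrile and the added carbon all change in this one step, so their separate contributions remain unresolved, as does the outcome of placing a carboxylic acid or a tetrazole on the same carbonyl carbon. Going by these compounds, it is also open whether cyano(phenylsulfonyl)methyl would give a step of similar size on compound 3, which has hydrogen in place of methoxy, or on compound 2, which carries the nitro group.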